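The compounds below may be only part of what the source reports. "The series", "measured", "known", "first", "only" and "open" are said of these compounds alone.

Working notes on the series. In an ADME assay on MDCK-II cells (Canis lupus familiaris) for permeability (on this read-out higher numbers stand for higher permeability and lower numbers for lower permeability), compound 1 `N#CC[C@]1(n2cc(-c3nc(-c4cn[nH]c4)cn4nccc34)cn2)C[C@H](C#N)C1` gives 7 10^-6 cm/s and compound 2 `N#CC[C@]1(n2cc(-c3nc(-c4cc[nH]n4)cn4nccc34)cn2)C[C@@H](C#N)C1` gives 7 10^-6 cm/s, so compound 2 stands level with compound 1, within the scatter. Compound 3 `N#CC[C@]1(n2cc(-c3nc(-c4cn[nH]c4)cn4nccc34)cn2)C[C@@H](C#N)C1` is still to be measured. It differs from compound 2 by 1H-pyrazol-4-yl in place of 1H-pyrazol-3-yl on an aromatic carbon, with the same atoms joined differently. Among the measured compounds shown here, no step between measured compounds is available to size this change, so the two level values are the only guide. No step beyond the scatter is expected in this assay, and neither direction is favoured, given compound 1 at 7 10^-6 cm/s and compound 2 at 7 10^-6 cm/s. The expected change is no change at the digits printed from compound 2 to compound 3 (within the scatter). The estimate for compound 3 is 7 10^-6 cm/s, with an expected range of 3.5 10^-6 cm/s to 14 10^-6 cm/s.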

Compound 3, apparent permeability in the MDCK-II assay: 6 10^-6 cm/s
Compound 3: middle estimate off by 1.2-fold (0.07 log units), on the high side, within the range that was stated.
By their numbers in the MDCK-II assay, from the lowest: compounds 3, 1 and 2 (each within the scatter of the next).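

In the MDCK-II assay compound 2 gives 7 10^-6 cm/s and compound 3 gives 6 10^-6 cm/s. In the MDCK-II assay the exchange at the aromatic carbon next to the ring nitrogen, 1H-pyrazol-4-yl in place of 1H-pyrazol-3-yl, gives a 1.2-fold lower number from compound 2 to compound 3 (0.07 log units; within the scatter) and thus no step beyond the scatter for this rearrangement of the same atoms. Among the compounds shown here, in the MDCK-II assay the mirror-image pair gives a 1.2-fold lower number from compound 1 to compound 3 (0.07 log units; within the scatter) and adds a first reading on configuration, which also shows no step beyond the scatter: the fact that compounds 1 and 3 differ only in the configuration as drawn. In a physicochemical assay for lipophilicity, using the shake flask method, in phosphate buffer, measured as octanol-water partition, at pH 7.4 (a lower number here means a more polar compound, a higher number a more lipophilic compound), compound 2 gives 1.7 and compound 3 gives 1.6. In the physicochemical assay the same pyrazole exchange gives a number 0.10 log units lower from compound 2 to compound 3 (within the scatter) and therefore also stays within the scatter.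

Going by these compounds, whether a group of another kind at this aromatic carbon, such as an amine or a carboxylic acid, would give a step beyond the scatter remains open. The compounds shown also leave open whether the mirror-image comparison would read the same with 1H-pyrazol-3-yl in place.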